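Lengthening the Ester Group on the Side Chain

The compounds below may be only part of what the source reports. "The series", "measured", "known", "first", "only" and "open" are said of these compounds alone.

Compound 1 `COc1ccc(O)c2c1C(=O)C=C(CCC=C(C)C)C2=O` carries a plain side chain on the shared core; in a functional assay on LNCaP cells (Homo sapiens) for cytotoxicity, read by MTT assay, with a stated time of 48 h (a lower number here means a stronger inhibitor, a higher number a weaker inhibitor), compound 1 gives 10900 nM. Compound 2 `COc1ccc(O)c2c1C(=O)C=C([C@H](CC=C(C)C)OC(C)=O)C2=O` adds an acetoxy group to that chain, and compound 2 gives 11000 nM. For the measured compounds named here, the only step measured so far, a 1.0-fold higher number from compound 1 to compound 2 (0.00 log units; within the scatter), shows that placing the acetoxy group there left the number essentially unchanged. On the values shown, compound 2 stands level with compound 1, the two numbers not told apart within the scatter.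

Compound 3 `COc1ccc(O)c2c1C(=O)C=C([C@H](CC=C(C)C)OC(=O)C=C(C)C)C2=O` keeps everything of compound 2 except the ester: 2-methylprop-1-en-1-yl in place of methyl on a carbonyl carbon. Going by the values given here, no measured step covers this kind of change; the one step that bears on the ester region, a 1.0-fold higher number from compound 1 to compound 2 (0.00 log units; within the scatter), concerns installing the acetoxy group rather than enlarging it, and that step was flat. With the whole ester apparently tolerated without effect, the expectation is that lengthening its acyl part to a (2-methylprop-1-en-1-yl)carbonyl will again move the number little, so the step of a 1.1-fold lower number from compound 2 to compound 3 (0.04 log units; within the scatter) is expected to stay within the scatter. Compound 3 is therefore estimated at 10000 nM, with a plausible range from 4000 nM to 25000 nM.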

Compound 3, half-maximal inhibitory concentration: 11400 nM
Compound 3: middle estimate off by 1.1-fold (0.06 log units), on the low side; measured number inside the range.
By their numbers in this assay, from the lowest: compounds 1, 2 and 3 (each within the scatter of the next).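

In this assay, replacing the methyl of the ester with 2-methylprop-1-en-1-yl on the carbonyl carbon brings in four carbons for one and adds a double bond outside any ring, yet the result is a 1.0-fold higher number from compound 2 to compound 3 (0.02 log units; within the scatter), so compound 2 and compound 3 cannot be told apart. For the compounds shown here, compound 2 showed only that a small acetoxy group on this saturated chain carbon made no measurable difference, and the larger ((2-methylprop-1-en-1-yl)carbonyl)oxy group now gives the same picture against the plain chain, with a 1.0-fold higher number from compound 1 to compound 3 (0.02 log units; within the scatter). There is no separate measurement that would explain why the number stays level across such different ester groups.

The level picture rests on compound 1, compound 2 and compound 3 alone, so it cannot be extended to other kinds of group at this carbon. A free hydroxyl, an amine, a benzoyl ester or a much longer acyl chain such as octanoyl could still separate from these three, and the present numbers give no way to tell.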